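Side-chain swaps and cytotoxicity on the shared core

The compounds below may be only part of what the source reports. "The series", "measured", "known", "first", "only" and "open" are said of these compounds alone.

Compound 1 `O=C1CNC(=O)N1C[C@H]1CN(c2ccc(-n3cc(-c4ccccn4)cn3)c(F)c2)C(=O)O1` is tested in an ADME assay on HEK293-A cells (Homo sapiens) for cytotoxicity, read by MTT assay, with a stated time of 48 h; a higher number here means a weaker inhibitor, a lower number a stronger inhibitor. For compound 1 the value > 400 ug/mL is a limit of the assay, not a number. Compound 2 `O=C1CSC(=O)N1C[C@H]1CN(c2ccc(-n3cc(-c4ccccn4)cn3)c(F)c2)C(=O)O1` gives 283 ug/mL, and compound 3 `CCC(=O)NC[C@H]1CN(c2ccc(-n3cc(-c4ccccn4)cn3)c(F)c2)C(=O)O1` gives 389 ug/mL. The step of an at least 1.4-fold lower number from compound 1 to compound 2 (0.15 log units; that floor lies within the scatter) and the step of an at least 1.0-fold lower number from compound 1 to compound 3 (0.01 log units; that floor lies within the scatter) both rest on that limit, and the step of a 1.4-fold higher number from compound 2 to compound 3 (0.14 log units; within the scatter) lies within the scatter, so no swap at this position has shifted the read-out beyond the scatter. Compound 4 `COC(=O)NC[C@H]1CN(c2ccc(-n3cc(-c4ccccn4)cn3)c(F)c2)C(=O)O1` is not yet measured; it differs from compound 1 by (methoxycarbonyl)amino in place of 2,5-dioxoimidazolidin-1-yl on a saturated chain carbon bound to a saturated ring carbon. The step to compound 3, which also replaces the ring with an open chain, is the nearest comparison. For compound 4 the expected step is a number no higher from compound 1 to compound 4 (the limit leaves the size open), none beyond the scatter. Compound 4 is therefore estimated at 400 ug/mL, with a range from 250 ug/mL to 650 ug/mL, and a result reported only as a limit would not surprise.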

Compound 4, half-maximal inhibitory concentration: 306 ug/mL
For compound 4 the middle estimate is 1.3-fold (0.12 log units) above the measured one, within the range that was stated.
By their numbers in this assay, from the lowest: compounds 2, 4 and 3 (each within the scatter of the next). At a limit, above all of these: compound 1.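

In this assay, methoxy in place of ethyl on a carbonyl carbon gives a 1.3-fold lower number from compound 3 to compound 4 (0.10 log units; within the scatter). Exchanging 2,4-dioxo-1,3-thiazolidin-3-yl for (methoxycarbonyl)amino gives a 1.1-fold higher number from compound 2 to compound 4 (0.03 log units; within the scatter). Compound 1 holds a limit, not a number, so an at least 1.3-fold lower number from compound 1 to compound 4 (0.11 log units; that floor lies within the scatter) rests on that limit and cannot be read for size: the limit of > 400 ug/mL in this assay, at which 1 of the 4 values shown sits.

As far as these compounds go, whether any group at this position can move the read-out beyond the scatter stays open. An amine, a carboxylic acid or a longer chain on the saturated chain carbon bound to a saturated ring carbon would test this.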